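Methoxy for chloro on the aryl of compound 2

The compounds below may be only part of what the source reports. "The series", "measured", "known", "first", "only" and "open" are said of these compounds alone.

Measured compounds:
compound 1 `CCCCCSc1nc2ccccc2n1CC(=O)O`, 1240 nM
compound 2 `O=C(O)Cn1c(SCc2cccc(Cl)c2)nc2ccccc21`, 186 nM
compound 3 `O=C(O)Cn1c(SCc2ccccc2Cl)nc2ccccc21`, 370 nM

In an assay on HEK293 cells for displacement of a labelled ligand from prostaglandin D2 receptor 2 (Homo sapiens) (on this read-out higher numbers stand for weaker inhibition and lower numbers for stronger inhibition), compound 2 gives the lowest number of the three, but compound 3 lies within the scatter of it, with a 2.0-fold higher number from compound 2 to compound 3 (0.30 log units; within the scatter); only compound 1 is clearly apart, with a 6.7-fold lower number from compound 1 to compound 2 (0.82 log units; beyond the scatter) and a 3.4-fold lower number from compound 1 to compound 3 (0.53 log units; beyond the scatter). Compound 4 `COc1cccc(CSc2nc3ccccc3n2CC(=O)O)c1` keeps the shared core and differs from compound 2 in one place: methoxy in place of chloro on an aromatic carbon.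

Among the compounds with values here, no measured step changes the group on the aryl ring itself; the steps between compound 1 and compound 2 and compound 3 concern the aryl in place of butyl, and the step between compound 2 and compound 3 concerns the position of chloro. That last step is the closest guide, and it stayed within the scatter, so the expected step to compound 4 is small, leaning slightly toward a higher number, as a 1.6-fold higher number from compound 2 to compound 4 (0.21 log units; within the scatter). Compound 4 is therefore estimated at 300 nM, in the range 120 nM to 900 nM.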

Compound 4, half-maximal inhibitory concentration: 72 nM
Compound 4: the middle estimate sits 4.2-fold (0.62 log units) above what was measured, outside the stated range (below it).
By their numbers in this assay, from the lowest: compound 4; then compounds 2 and 3 (each within the scatter of the next); then compound 1.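

In this assay, methoxy in place of chloro on an aromatic carbon, meta to a large group, gives a 2.6-fold lower number from compound 2 to compound 4 (0.41 log units; beyond the scatter) and moves the number beyond the scatter. The earlier compounds shown here showed the effect of replacing butyl with a chlorophenyl group and of moving the chloro, a change that stayed within the scatter; this step shows that the identity of the group on this carbon can itself shift the number. Nothing available here accounts for the direction or size of this step.

Going by these compounds, it remains open whether methoxy would act in the same way on the aryl of compound 3. The compounds shown also leave open what an ethoxy, a hydroxy or a trifluoromethyl group would do on the same aromatic carbon as the methoxy of compound 4.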